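Cytotoxicity on Vero cells: an epimer of compound 1

The source may hold more compounds than are shown below. What is called first, only, known or untested is meant among the compounds shown, and "the series" means these compounds.

Measured compounds:
compound 1 `Cc1cn([C@H]2C[Se][C@@H](CO)O2)c(=O)[nH]c1=O` — > 100000 nM
compound 2 `Nc1ncnc2c1ncn2[C@H]1C[Se][C@@H](CO)O1` — > 100000 nM
compound 3 `Nc1nc(O)c2ncn([C@H]3C[Se][C@@H](CO)O3)c2n1` — > 100000 nM

In a functional assay on Vero cells (Chlorocebus sabaeus) for cytotoxicity (a higher number here means a weaker inhibitor, a lower number a stronger inhibitor), compound 1 gives > 100000 nM, which is a limit of the assay and not a number. Compound 2 also stands at the limit with > 100000 nM. Compound 3 likewise reaches only the limit, > 100000 nM. Among the measured compounds shown here, all three values sit at the limit of > 100000 nM in this assay, at which 3 of the 3 values shown sit, so compound 1 cannot be placed above or below the others; no step between measured compounds is known.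

Compound 4 `Cc1cn([C@@H]2C[Se][C@@H](CO)O2)c(=O)[nH]c1=O` differs from compound 1 in this way: the two compounds have the same atoms and bonds and differ only in configuration as drawn: 1 of 2 stereo elements differ; a stereocentre at a saturated ring carbon is drawn R in compound 1 and S in compound 4. For the measured compounds named here, with no measured step to draw on, the step of a number no higher from compound 1 to compound 4 (the limit leaves the size open) is expected to be none beyond the scatter. Compound 4 is therefore estimated to give 100000 nM in this assay, within 50000 nM to 200000 nM, most likely again reported as a limit.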

Compound 4, half-maximal inhibitory concentration: > 100000 nM
Compound 4: no number, only a limit; the forecaster's own chance of this, stated with the estimate: 85%; the middle value lies on the limit itself.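

No step can be read between compound 1 and compound 4 in this assay, as both results are limits of the assay and not numbers. The compounds shown leave open whether the configuration at the saturated ring carbon changes the result in this assay at all.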